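Bromo in place of fluoro on compound 3

The compounds below may be only part of what the source reports. "The series", "measured", "known", "first", "only" and "open" are said of these compounds alone.

In a functional assay on U-251 cells (Homo sapiens) for inhibition, read by sulforhodamine B assay, with a stated time of 48 h (on this read-out higher numbers stand for weaker inhibition of growth and lower numbers for stronger inhibition of growth), compound 1 `CCOC(=O)c1nn(-c2ccccc2)c(-c2ccc(F)cc2)c1CNC(C)(C)C` gives > 632000 nM; > 579000 nM (2 entries), and both entries are limits. Compound 2 `CCOC(=O)c1nn(-c2ccccc2)c(-c2ccc(Br)cc2)c1CNC(C)(C)C` gives 71900 nM; > 509000 nM (2 entries). Compound 3 `CC(C)(C)NCc1c(C(=O)O)nn(-c2ccccc2)c1-c1ccc(F)cc1` gives > 680000 nM, which is a limit, so it has no single number to stand on. Compound 4 `CC(C)(C)NCc1c(C(=O)O)nn(-c2ccccc2)c1-c1ccc(Br)cc1` differs from it by bromo in place of fluoro on an aromatic carbon, para to a large group: bromo in place of fluoro on an aromatic carbon. Compound 2 also carries bromo, and it alone has yielded a number, as the several entries of compound 2 in this assay, 71900 nM; > 509000 nM (2 entries) shows. The estimated step of an at least 1.5-fold lower number from compound 3 to compound 4 (0.17 log units; that floor lies within the scatter) is expected to stay within the scatter. Compound 4 is expected at 450000 nM, with an estimated range from 100000 nM to 620000 nM.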

Compound 4, concentration for 50% growth inhibition: 126000 nM
Compound 4: middle estimate off by 3.6-fold (0.55 log units), on the high side, and the stated range covers the measured number.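

With the carboxylic acid in place, 4-fluorophenyl to 4-bromophenyl gives an at least 5.3-fold lower number from compound 3 to compound 4 (0.73 log units; beyond the scatter), so this change at this position moves the read-out measurably. Compound 3 stands at > 680000 nM, which is a limit, so the size of the step is only a floor. The earlier bromo compound had left this unsettled, with one number and one limit: the several entries of compound 2 in this assay, 71900 nM; > 509000 nM (2 entries)

From the compounds shown here alone, whether chloro or iodo at this position would give a lower number remains open. So does whether the step would hold with a primary amide in place of the carboxylic acid.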